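Adding a methyl on the core of compound 1

A few compounds are considered here, and "the series" means these few. Any claim that something is new, unique, unknown or untested is made for them only; others in the source may bear on it.

Measured so far:
Compound 1 `O=C1c2cc(COc3ccccc3)nn2CCN1c1ccc(F)cc1` gives 79% in a functional assay on HEK293 cells for positive allosteric modulation of metabotropic glutamate receptor 5 (Homo sapiens), read by calcium flux; a lower number here means a smaller maximal response, a higher number a larger maximal response.
Compound 2 `Cc1ccc(N2CCn3nc(COc4ccccc4)cc3C2=O)cc1` gives 65% in this assay.

Among the compounds with values here, compound 1 stands highest of the two numbers; its only neighbour is compound 2, with a number 14 percentage points lower from compound 1 to compound 2 (beyond the scatter). Compound 3 `Cc1c(COc2ccccc2)nn2c1C(=O)N(c1ccc(F)cc1)CC2` differs from compound 1 as follows: methyl in place of hydrogen on an aromatic carbon. Within the data shown here, no measured step touches this ring carbon; the one known step concerns the fluoro on the aryl ring, so it gives no guide here. For compound 3 no step beyond the scatter is therefore expected, which is a number 4 percentage points lower from compound 1 to compound 3 (within the scatter). Compound 3 is thus estimated at 75%, between 50% and 98%.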

Compound 3, largest response reached (Emax), in percent of the reference or control that the assay uses: 32%
Estimate against measurement, compound 3: 43 percentage points above, and the stated range ends above it.
By their numbers in this assay, from the lowest: compound 3; then compound 2; then compound 1.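

The ring carbon next to the ring atom that bears a phenoxymethyl group turns out to be sensitive in this assay: methyl in place of hydrogen gives a number 47 percentage points lower from compound 1 to compound 3 (beyond the scatter). This single added carbon on the core of compound 1 moves the maximal response further than the change on the aryl ring, a number 14 percentage points lower from compound 1 to compound 2 (beyond the scatter). Nothing available explains this drop. As far as these compounds go, whether a chloro or an ethyl on this carbon would lower the response as far as methyl remains open, and so does whether the loss holds with methyl in place of fluoro on the aryl ring.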